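The source may hold more compounds than are shown below. What is called first, only, known or untested is meant among the compounds shown, and "the series" means these compounds.

Measured so far in an ADME assay on microsomes from liver (Rattus norvegicus) for metabolic stability, read by LC-MS, with a stated time of 45 min, tested at 2 uM; a higher number here means that more of the compound is left, a lower number that less of the compound is left:
- compound 1 (`Cc1cc(OCc2ccc(F)cc2F)c(Br)c(=O)n1Cc1ccc(CN(C)C)cc1`): 53%
- compound 2 (`Cc1cc(OCc2ccc(F)cc2F)c(Br)c(=O)n1Cc1ccc(C(=O)N(C)C)cc1`): 51%

Compound 2, at 51% in this read-out, stands level with compound 1 within the usual scatter, so neither ranks above the other. Compound 3 (`Cc1cc(OCc2ccc(F)cc2F)c(Br)c(=O)n1Cc1ccc(C(N)=O)cc1`) has not been measured yet. The change from compound 2 (amino in place of dimethylamino on a carbonyl carbon) puts amino in place of dimethylamino on a carbonyl carbon. Going by the values given here, only one measured step bears on this: a number 2 percentage points lower from compound 1 to compound 2 (within the scatter) is small, and it brought in the dimethylcarbamoyl group that now changes. Among the compounds with values here, that is thin evidence, since no measured pair shows this exact swap. No shift beyond the scatter is therefore expected in this assay for this change. The estimated step is a number 4 percentage points higher from compound 2 to compound 3 (within the scatter) and carries real uncertainty. For compound 3 the estimated value is 55% with an expected range from 38% to 74% in this read-out.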

Compound 3, percent of the compound remaining: 94%
Beside the measured number, compound 3's estimate is 39 percentage points below it; the whole stated range lies below it.
By their numbers in this assay, from the lowest: compounds 2 and 1 (each within the scatter of the next); then compound 3.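

In this assay, the amide at this position proves highly sensitive to what sits on its nitrogen: amino in place of dimethylamino on the carbonyl carbon gives a number 43 percentage points higher from compound 2 to compound 3 (beyond the scatter). A carbonyl alone does not account for this, since dimethylcarbamoyl in place of (dimethylamino)methyl gave a number 2 percentage points lower from compound 1 to compound 2 (within the scatter), while carbamoyl in place of the same group gives a number 41 percentage points higher from compound 1 to compound 3 (beyond the scatter). Nothing measured here explains why the compound with the carbamoyl group is left in so much greater amount.

Still open, from the compounds shown here alone, is whether methylamino on the carbonyl carbon would behave more like amino or more like dimethylamino. Going by these compounds, it is also open how a carboxylic acid in place of the carbamoyl group would fare.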